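A few compounds are considered here, and "the series" means these few. Any claim that something is new, unique, unknown or untested is made for them only; others in the source may bear on it.

Compound 2 `CO[C@@H](C[C@@H](C)[C@@H](O)/C=C/C=C/CNC(=O)C(C)(C)[C@H](O)/C(C)=C/C=C/C=C/C(C)=C(\C)[N+](=O)[O-])[C@]1(O)[C@@H](C)C(=O)N(C)[C@]12C(=O)O[C@@H]2C` stands only at a limit: in a functional assay on A549 cells (Homo sapiens) for cytotoxicity (on this read-out higher numbers stand for weaker inhibition and lower numbers for stronger inhibition), compound 2 gives > 100000 nM, a limit rather than a number. Compound 1 `COC(CC(C)C(O)/C=C/C=C/CNC(=O)C(C)(C)C(O)/C(C)=C\C=C/C=C/C(C)=C(\C)[N+](=O)[O-])C1(O)C(C)C(=O)N(C)C12C(=O)OC2C` also sits at a limit; in this assay compound 1 gives > 100000 nM. The step from compound 1 to compound 2, a step that the two limits leave unreadable from compound 1 to compound 2, cannot be read because of the limit of > 100000 nM in this assay, at which 2 of the 2 values shown sit. Compound 3 `CO[C@@H](C[C@@H](C)[C@@H](O)/C=C/C=C/CNC(=O)C(C)(C)[C@H](O)/C(C)=C\C=C\C=C\C(C)=C(/C)[N+](=O)[O-])[C@]1(O)[C@@H](C)C(=O)N(C)[C@]12C(=O)O[C@@H]2C` differs from compound 2 by the two compounds have the same atoms and bonds and differ only in configuration as drawn: 1 of 14 stereo elements differ; a double bond is drawn E in compound 2 and Z in compound 3. Among the measured compounds shown here, no measured step bears on a change of one double bond configuration, so no direction can be read; compound 3 is expected to remain near the limit, with an estimated step of a number no higher from compound 2 to compound 3 (the limit leaves the size open). Compound 3 is estimated at 100000 nM, range 30000 nM to 300000 nM.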

Compound 3, half-maximal inhibitory concentration: > 100000 nM
Compound 3 gave a limit, no number (the forecaster's own chance of this, stated with the estimate: 80%); the middle value lies on the limit itself.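

Compound 3 gives > 100000 nM in this assay, a limit and not a number. The steps linking compounds 1, 2 and 3 therefore cannot be read. Going by these compounds, whether the double bond drawn E in compound 2 and Z in compound 3 matters at all in this assay stays open.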